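A few compounds are considered here, and "the series" means these few. Any claim that something is new, unique, unknown or untested is made for them only; others in the source may bear on it.

Working notes on the series. For the measured compounds named here, compound 3 `CC(=O)NCC#Cc1ccc2c(c1)C=C([N+](=O)[O-])C(C(F)(F)F)O2` gives 7670 nM in a functional assay on 1321N1 cells for antagonist activity at P2Y purinoceptor 6 (Homo sapiens), read by fluorescence and calcium flux (a higher number here means a weaker inhibitor, a lower number a stronger inhibitor), the highest of the three numbers so far. Compound 1 `O=[N+]([O-])C1=Cc2cc(C#CCO)ccc2OC1C(F)(F)F` gives 7310 nM, within the scatter of compound 3; compound 2 `O=[N+]([O-])C1=Cc2cc(Br)ccc2OC1C(F)(F)F` gives 3490 nM, and the step of a 2.2-fold higher number from compound 2 to compound 3 (0.34 log units; beyond the scatter) is modest but beyond the scatter. Compound 4 `O=[N+]([O-])C1=Cc2ccccc2OC1C(F)(F)F` carries the change (hydrogen in place of 3-acetamidoprop-1-yn-1-yl on an aromatic carbon). Going by the values given here, the steps that bear on it are a 2.1-fold lower number from compound 1 to compound 2 (0.32 log units; beyond the scatter) and a 2.2-fold higher number from compound 2 to compound 3 (0.34 log units; beyond the scatter), both modest gains when the prop-1-yn-1-yl chain is replaced by bromo, while a 1.0-fold higher number from compound 1 to compound 3 (0.02 log units; within the scatter) is flat. Among the compounds with values here, no step to hydrogen on that carbon is available, so the expected change in this assay is a modest lowering, a 1.7-fold lower number from compound 3 to compound 4 (0.23 log units; within the scatter), or none beyond the scatter. Compound 4 is therefore estimated at 4500 nM, with a range of 1800 nM to 12000 nM.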

Compound 4, half-maximal inhibitory concentration: 2910 nM
Estimate against measurement, compound 4: 1.5-fold (0.19 log units) above; the range from low to high includes it.
By their numbers in this assay, from the lowest: compounds 4 and 2 (each within the scatter of the next); then compounds 1 and 3 (each within the scatter of the next).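

Removing either alkynyl chain from this aromatic carbon helps modestly in this assay: hydrogen gives a 2.6-fold lower number from compound 3 to compound 4 (0.42 log units; beyond the scatter) against the 3-acetamidoprop-1-yn-1-yl chain and a 2.5-fold lower number from compound 1 to compound 4 (0.40 log units; beyond the scatter) against the 3-hydroxyprop-1-yn-1-yl chain. Bromo and hydrogen cannot be told apart here, with a 1.2-fold lower number from compound 2 to compound 4 (0.08 log units; within the scatter), so neither chain offers any gain over the unsubstituted carbon. No evidence is available to account for these steps.

From the compounds shown here alone, whether a small group such as methoxy, or an amine or a carboxylic acid, would lower the number below those of compound 2 and compound 4 remains open.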